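From 4-fluorophenyl to 4-(methylsulfanyl)phenyl: notes on compound 4

This account rests on a few compounds, and the source may have more. Where it says the series, first, only, none or still open, it means among the compounds named here.

In a functional assay on MCF-A cells (Homo sapiens) for cytotoxicity (a lower number here means a stronger inhibitor of growth, a higher number a weaker inhibitor of growth), compound 1 (`CSc1ccc(C2=C(c3ccc(F)c(C)c3)C(=O)N3CCCC3C2)cc1`) gives 500 nM as a measured number. Compound 3 (`CSc1ccc(C2=C(c3ccc(F)cc3)C(=O)N3CCCC3C2)cc1`) gives 800 nM on the same shared core. Hydrogen in place of methyl on an aromatic carbon gives a 1.6-fold higher number from compound 1 to compound 3 (0.20 log units; within the scatter) so these two values stand together. Compound 2 (`CSc1ccc(C2=C(c3ccc(O)cc3)C(=O)N3CCCC3C2)cc1`) gives > 100000 nM and this is a limit of the assay, not a number.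

The step under consideration leads to compound 4 (`CSc1ccc(C2=C(c3ccc(SC)cc3)C(=O)N3CCCC3C2)cc1`), with methylsulfanyl in place of fluoro on an aromatic carbon, para to a large group (methylsulfanyl in place of fluoro on an aromatic carbon). Two large steps bear on this place: an at least 120-fold lower number from compound 2 to compound 3 (2.09 log units; beyond the scatter) with fluoro in place of hydroxy, and an at least 200-fold higher number from compound 1 to compound 2 (2.30 log units; beyond the scatter) with 4-hydroxyphenyl in place of 4-fluoro-3-methylphenyl. Both involve the hydroxy compound and its limit, and neither tests methylsulfanyl. Compound 4 carries no hydroxy, like compound 3 at 800 nM so a loss of that size is not expected. Some room is left towards a higher number in this assay since this group is untested. The expected change is a 1.3-fold higher number from compound 3 to compound 4 (0.10 log units; within the scatter) and no step beyond the scatter is anticipated. For compound 4 the estimated value is 1000 nM (expected range 250 nM to 5000 nM).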

Compound 4, concentration for 50% growth inhibition: 8000 nM
The estimate for compound 4 lay 8.0-fold (0.90 log units) below the measured number; the measured number lies above the stated range.
By their numbers in this assay, from the lowest: compounds 1 and 3 (each within the scatter of the next); then compound 4. At a limit, above all of these: compound 2.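

In this assay methylsulfanyl in place of fluoro gives a step beyond the scatter (a 10-fold higher number from compound 3 to compound 4 (1.00 log units; beyond the scatter)), so a clear change at this place on the aromatic ring is not confined to the hydroxy compound. Compound 4 also stands apart from the methyl-bearing compound (a 16-fold higher number from compound 1 to compound 4 (1.20 log units; beyond the scatter)) and from the hydroxy compound (an at least 12-fold lower number from compound 2 to compound 4 (1.09 log units; beyond the scatter)), which puts methylsulfanyl on a rung of its own among the groups shown at this place. The step from the hydroxy compound is read against a limit, not a number, and that limit belongs to compound 2: the limit of > 100000 nM in this assay, at which 1 of the 4 values shown sits.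

Fluoro, hydroxy and methylsulfanyl are too few to give a trend, and it stays open whether a methoxy group, a chlorine or a longer chain such as ethylsulfanyl at this place would fall with compound 3 or with compound 4. Also open, going by these compounds, are whether an amine or a carboxylic acid here would go as far as compound 2, and what the methyl group of compound 1 would do in a compound that carries methylsulfanyl at this place.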